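Swapping ethynyl for methoxy near the assay limit

A few compounds are considered here, and "the series" means these few. Any claim that something is new, unique, unknown or untested is made for them only; others in the source may bear on it.

Compound 1 `O=C(CCc1cccc2c1B(O)OC2)Nc1ccc(I)cc1` and compound 2 `C#Cc1ccc(NC(=O)CCc2cccc3c2B(O)OC3)cc1` share one core and differ in a single group. In an ADME assay on WI-38 cells (Homo sapiens) for cytotoxicity, read by MTT assay, with a stated time of 72 h (on this read-out higher numbers stand for weaker inhibition and lower numbers for stronger inhibition), compound 1 gives 49000 nM. Compound 2 gives > 100000 nM, which is a limit of the assay and not a number. Compound 2 therefore stands at the limit of > 100000 nM in this assay, at which 1 of the 2 values shown sits.

Compound 3 `COc1ccc(NC(=O)CCc2cccc3c2B(O)OC3)cc1` keeps the same core and changes one group: methoxy in place of ethynyl on an aromatic carbon. Here methoxy sits in place of ethynyl on an aromatic carbon, para to a large group.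

Within the data shown here, one measured step bears on this change, since it involves the same carbon: an at least 2.0-fold higher number from compound 1 to compound 2 (0.30 log units; that floor lies within the scatter). That step brought in ethynyl in place of iodo, so it says nothing directly about methoxy, and its floor lies within the scatter. Resting on that step alone, no shift beyond the scatter is expected in this assay, and no direction can be favoured with confidence. The expected step is an at least 1.2-fold lower number from compound 2 to compound 3 (0.09 log units; that floor lies within the scatter). Compound 3 is estimated at 80000 nM, with an expected range from 35000 nM to 160000 nM.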

Compound 3, half-maximal inhibitory concentration: > 100000 nM
Compound 3 ended at the assay's limit; the forecaster's own chance of this, stated with the estimate: 50%; at least 1.2-fold (0.09 log units) between middle value and limit.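

In this assay, methoxy on the aromatic carbon para to a large group leaves compound 3 at a limit of the assay and not at a number, so two different groups at this place now share the same ceiling: the limit of > 100000 nM in this assay, at which 2 of the 3 values shown sit.

The step between compound 2 and compound 3 cannot be read, so the hydrogen-bond acceptor that methoxy brings and ethynyl lacks produces no visible difference in this read-out. Replacing iodo with methoxy gives an at least 2.0-fold higher number from compound 1 to compound 3 (0.30 log units; that floor lies within the scatter), so this second replacement, like the earlier one with ethynyl, shows no shift that can be told from the scatter.

Only compound 1 gives a true number, at 49000 nM. From the compounds shown here alone, how far the other two compounds lie past the limit stays unknown, which leaves open whether ethynyl and methoxy really differ here. Going by these compounds, it is also open whether an amine or a carboxylic acid on the same carbon would give a value that can be read, which would show how much this position matters in this assay.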